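The source may report more compounds than this note shows. Statements on the series, on what has been measured and on what is new or still open speak of the compounds shown alone.

Compound 1 `COc1cc(-c2cc(C(=O)O)c3ccccc3n2)ccc1OCC(=O)Nc1cccc(C)c1`: 225000 nM
Compound 2 `COc1cc(-c2cc(C(=O)O)c3ccccc3n2)ccc1OCC(=O)Nc1cccc(C(F)(F)F)c1`: 160000 nM
Compound 3 `COc1cc(-c2cc(C(=O)O)c3ccccc3n2)ccc1OCC(=O)Nc1ccc(C(F)(F)F)cc1`: 150000 nM

In an ADME assay on HaCaT cells (Homo sapiens) for inhibition (a higher number here means a weaker inhibitor, a lower number a stronger inhibitor), compound 1 gives the highest of the three numbers, yet the steps of a 1.4-fold lower number from compound 1 to compound 2 (0.15 log units; within the scatter) and a 1.5-fold lower number from compound 1 to compound 3 (0.18 log units; within the scatter) both lie within the scatter, so no order among the three compounds can be read from these values. Compound 4 `COc1cc(-c2cc(C(=O)O)c3ccccc3n2)ccc1OCC(=O)NCc1ccccc1` differs from compound 1 by benzyl in place of 3-methylphenyl on an amide-type nitrogen. Among the measured compounds shown here, no measured step makes a change of this kind; every measured step, including a 1.1-fold lower number from compound 2 to compound 3 (0.03 log units; within the scatter), only swaps one aryl group for another on the amide-type nitrogen, and all of them stay within the scatter. The number for compound 4 is therefore expected to stay close to that of compound 1, with a step of no change at the digits printed from compound 1 to compound 4 (within the scatter) not expected to go beyond the scatter. Compound 4 is estimated at 225000 nM, within a range from 110000 nM to 450000 nM.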

Compound 4, half-maximal inhibitory concentration: > 300000 nM
Compound 4 gave a limit, no number; the forecaster's own chance of this, stated with the estimate: 20%; middle value at least 1.3-fold (0.12 log units) away from the limit.
By their numbers in this assay, from the lowest: compounds 3, 2 and 1 (each within the scatter of the next). At a limit, above all of these: compound 4.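

In this assay, compound 4 gives only a limit, not a number: the limit of > 300000 nM in this assay, at which 1 of the 4 values shown sits. This is the first change shown that puts benzyl rather than an aryl ring on the amide-type nitrogen, and its size is known only as a floor: an at least 1.3-fold higher number from compound 1 to compound 4 (0.12 log units; that floor lies within the scatter), an at least 1.8-fold higher number from compound 2 to compound 4 (0.27 log units; that floor lies within the scatter) and an at least 2.0-fold higher number from compound 3 to compound 4 (0.30 log units; that floor lies within the scatter). Each floor lies within the scatter, so benzyl may or may not truly differ from the aryl groups.

As far as these compounds go, how far compound 4 lies past its limit remains open. So does whether a longer chain such as 2-phenylethyl on this nitrogen, or an amine on the benzyl ring, would give a measurable number.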